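A few compounds are considered here, and "the series" means these few. Any claim that something is new, unique, unknown or untested is made for them only; others in the source may bear on it.

Compound 2 `Cc1ccnc(/C(N)=N/NC(=S)N2CCOCC2)c1` gives 87.4% in a functional assay on A-375 cells (Homo sapiens) for cytotoxicity, read by MTT assay, with a stated time of 72 h, tested at 30 uM (a higher number here means more inhibition of growth at the concentration tested, a lower number less inhibition of growth), the highest of the three numbers measured. Compound 1 `N/C(=N\NC(=S)N1CCOCC1)c1ccccn1` gives 15% in this assay, and the only difference between the two is a methyl in place of hydrogen on an aromatic carbon, a change of a number 72.4 percentage points higher from compound 1 to compound 2 (beyond the scatter). Compound 3 `Cc1ccnc(/C(N)=N/NC(=S)N2CCCCCC2)c1` gives 76.5% in this assay; it carries the same methyl as compound 2 and differs from it only in the ring on the thiocarbonyl carbon, and its number lies beyond the scatter below that of compound 2.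

Compound 4 `Cc1ccnc(/C(N)=N/NC(=S)N2CCCCC2)c1` has not been measured. It differs from compound 2 by piperidin-1-yl in place of morpholin-4-yl on a thiocarbonyl carbon. Within the data shown here, no measured step covers exactly this swap; the nearest comparison is compound 2 against compound 3, where changing the ring on the thiocarbonyl carbon lowered the number moderately. A small drop, or no change beyond the scatter, is therefore expected. Compound 4 is expected to give about 80%, within a range from 62% to 92%. The expected step is a number 7.4 percentage points lower from compound 2 to compound 4 (within the scatter).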

Compound 4, percent growth inhibition at one concentration: 80%
Estimate against measurement, compound 4: no gap at the digits printed; measured number inside the range.
By their numbers in this assay, from the lowest: compound 1; then compounds 3, 4 and 2 (each within the scatter of the next, the first and the last beyond it).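

Putting piperidin-1-yl in place of morpholin-4-yl on the thiocarbonyl carbon gives a number 7.4 percentage points lower from compound 2 to compound 4 (within the scatter) in this assay. The oxygen of the morpholin-4-yl ring, the one hydrogen-bond acceptor it counts, can therefore be replaced by carbon at this position without a change beyond the scatter. The ring on the thiocarbonyl carbon thus tolerates this swap when the methyl is present, a much smaller step than the one that methyl produced. Nothing measured here explains why these two rings give values within the scatter of each other.

From the compounds shown here alone, all of these ring comparisons carry the methyl, so it remains open whether the swap would behave the same way without it. Also open, going by these compounds, is what a piperazin-1-yl ring or an open-chain dimethylamino group would give on the thiocarbonyl carbon.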